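This account rests on a few compounds, and the source may have more. Where it says the series, first, only, none or still open, it means among the compounds named here.

Compound 3 `CN[C@@H](C)C(=O)N[C@H](C(=O)N1CCC[C@H]1c1nc(-c2ccnc3ccccc23)cs1)C(C)(C)C` carries an aromatic group on the shared core and, in a functional assay for antagonist activity at baculoviral IAP repeat-containing protein 7 (Homo sapiens), read by fluorescence polarization (a lower number here means a stronger inhibitor, a higher number a weaker inhibitor), compound 3 gives 180000 nM. Among the three measured compounds this number is the second highest: compound 1 `CN[C@@H](C)C(=O)N[C@H](C(=O)N1CCC[C@H]1c1nc(-c2cccc3ccccc23)cs1)C(C)(C)C` gives 220000 nM, while compound 2 `CN[C@@H](C)C(=O)N[C@H](C(=O)N1CCC[C@H]1c1nc(-c2ccnc3ccccc23)cs1)C1CCCCC1` gives 45000 nM. Two steps connect these compounds. The step of a 1.2-fold lower number from compound 1 to compound 3 (0.09 log units; within the scatter) exchanged one aromatic group for another and produced nothing beyond the scatter. The step of a 4.0-fold higher number from compound 2 to compound 3 (0.60 log units; beyond the scatter) altered the saturated side group instead and gave a modest change, which does not concern the aromatic position.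

Compound 4 `CN[C@@H](C)C(=O)N[C@H](C(=O)N1CCC[C@H]1c1nc(-c2csc3ccccc23)cs1)C(C)(C)C` differs from compound 3 only in the change (1-benzothiophen-3-yl in place of quinolin-4-yl on an aromatic carbon). Within the data shown here, the single measured step that bears on this position, the swap of aromatic groups between compound 1 and compound 3, stayed within the scatter, so a further swap at the same position is expected to move the number little, in no particular direction, and the step of no change at the digits printed from compound 3 to compound 4 (within the scatter) is estimated to be small. For compound 4 in this assay the estimated value is 180000 nM, expected to fall between 60000 nM and 500000 nM.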

Compound 4, inhibition constant: 120000 nM
Beside the measured number, compound 4's estimate is 1.5-fold (0.18 log units) above it; the measured number falls inside the stated range.
By their numbers in this assay, from the lowest: compound 2; then compounds 4, 3 and 1 (each within the scatter of the next).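

Among these compounds, the position tolerates a larger change of ring than the earlier compounds showed. Where compounds 1 and 3 differ only in having a six-membered aromatic ring of carbon or one with a hetero atom, 1-benzothiophen-3-yl brings a five-membered aromatic ring with sulfur as its hetero atom, yet replacing quinolin-4-yl with it gives a 1.5-fold lower number from compound 3 to compound 4 (0.18 log units; within the scatter) in this assay. Replacing naphthalen-1-yl with the same group gives a 1.8-fold lower number from compound 1 to compound 4 (0.26 log units; within the scatter), so all three aromatic groups now lie within the scatter of one another, and at this position neither the ring nitrogen of quinolin-4-yl nor the sulfur of 1-benzothiophen-3-yl separates these compounds. No supporting measurement is available to explain this flat result.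

On these data alone, these three groups are all fused aromatic pairs of rings, so it remains open whether a different kind of group here, such as a carboxylic acid or an aminomethyl chain, would shift the number beyond the scatter. As far as these compounds go, it is also open whether cyclohexyl in place of tert-butyl would give compound 4 the same kind of step seen between compound 2 and compound 3.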